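This account rests on a few compounds, and the source may have more. Where it says the series, first, only, none or still open, it means among the compounds named here.

Measured in an ADME assay on MDCK cells (Canis lupus familiaris) for cytotoxicity, read by MTT assay, with a stated time of 48 h; on this read-out higher numbers stand for lower toxicity in this test and lower numbers for higher toxicity in this test:
- Compound 1 `Cc1cccc(NC(=O)CSc2nc(-c3ccccc3)cc(-c3ccccc3)c2C#N)c1`: > 250000 nM (a limit)
- Compound 2 `CC[C@H](C)[C@H](NC(=O)CSc1nc(-c2ccccc2)cc(-c2ccc(C)cc2)c1C#N)C(=O)OC`: > 250000 nM (a limit)
- Compound 3 `Cc1ccc(-c2cc(-c3ccccc3)nc(SCC(=O)N[C@H](C(=O)N[C@@H](CC(=O)O)C(=O)O)C(C)C)c2C#N)cc1`: > 250000 nM (a limit)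

None of these three readings is a number. Compound 2, the starting point here, stands at > 250000 nM in this assay, and this is only a limit of the assay. Compound 4 `Cc1ccc(-c2cc(-c3ccccc3)nc(SCC(=O)O)c2C#N)cc1` has yet to be measured in this assay.

Compound 4 departs from compound 2 in one place, with hydroxy in place of (1-(methoxycarbonyl)-2-methylbutyl)amino on a carbonyl carbon. Compound 1, compound 2 and compound 3 carry different groups on that carbonyl carbon, yet no reading separates them: the limit of > 250000 nM in this assay, at which 3 of the 3 values shown sit. Going by the values given here, no measured pair offers a step to go by, so the expectation rests on this shared limit alone.

The expected result is a number no higher from compound 2 to compound 4 (the limit leaves the size open), which would be no change beyond the scatter in either direction. A reading that again gives only a limit is considered the likeliest outcome. For compound 4 the estimated value is 250000 nM, with an expected range from 120000 nM to 400000 nM.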

Compound 4, half-maximal cytotoxic concentration: > 250000 nM
Compound 4 ended at the assay's limit; the forecaster's own chance of this, stated with the estimate: 80%; the middle value lies on the limit itself.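

In this assay compound 4 gives > 250000 nM as a limit of the assay, not a number. Compound 2 also stands at a limit, so no step can be read between compound 2 and compound 4. The compounds shown leave open at what concentration any of them would reach the half-maximal cytotoxic effect, as all share one reading: the limit of > 250000 nM in this assay, at which 4 of the 4 values shown sit.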